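Amine nitrogen groups on the shared core

The source may report more compounds than this note shows. Statements on the series, on what has been measured and on what is new or still open speak of the compounds shown alone.

Values so far in a functional assay on HEL cells (Homo sapiens) (a lower number here means that less compound is tolerated, a higher number that more compound is tolerated), for two compounds
compound 1 (`Cc1cn([C@@H]2O[C@H](CO[Si](C)(C)C(C)(C)C)[C@@]3(OS(=O)(=O)C=C3NCC(=O)C(=O)N3CCC3)[C@H]2O[Si](C)(C)C(C)(C)C)c(=O)n(C)c1=O`) gives 84400 nM as a number
compound 2 (`Cc1cn([C@@H]2O[C@H](CO[Si](C)(C)C(C)(C)C)[C@@]3(OS(=O)(=O)C=C3NC(=O)NC(=O)c3ccccc3)[C@H]2O[Si](C)(C)C(C)(C)C)c(=O)n(C)c1=O`) gives >= 200000 nM as a limit of the assay

Compound 2 stands at the limit of >= 200000 nM in this assay, at which 1 of the 2 values shown sits, and that is a limit, not a number. Compound 3 (`Cc1cn([C@@H]2O[C@H](CO[Si](C)(C)C(C)(C)C)[C@@]3(OS(=O)(=O)C=C3NCCC(N)=O)[C@H]2O[Si](C)(C)C(C)(C)C)c(=O)n(C)c1=O`) has 2-carbamoylethyl in place of benzoylcarbamoyl on an amine nitrogen and keeps the shared core. Among the measured compounds shown here, only one measured step bears on this position, namely an at least 2.3-fold higher number from compound 1 to compound 2 (0.37 log units; beyond the scatter) and it is modest in size, with one end resting on a limit. Like compound 1 at 84400 nM and unlike compound 2, compound 3 lacks benzoylcarbamoyl. For the measured compounds named here, on that thin basis a modest move to a lower number is expected in this assay and it should be of about the size of the one measured step. The estimated change is an at least 1.8-fold lower number from compound 2 to compound 3 (0.25 log units; that floor lies within the scatter) and it is reckoned against a limit, so it carries wide uncertainty. For compound 3 the estimate is 110000 nM with an expected range from 45000 nM to 200000 nM in this series.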

Compound 3, half-maximal cytotoxic concentration: 14800 nM
For compound 3 the middle estimate is 7.4-fold (0.87 log units) above the measured one, and the stated range ends above it.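

In this assay, among the compounds shown here, this position on the amine nitrogen turns out to have a wider span than compounds 1 and 2 suggested, with an at least 13-fold lower number from compound 2 to compound 3 (1.13 log units; beyond the scatter) as the largest step so far. Removing benzoylcarbamoyl does not by itself set the level, since the two compounds without it are also far apart, with a 5.7-fold lower number from compound 1 to compound 3 (0.76 log units; beyond the scatter) on a saturated chain carbon bound to the amine nitrogen, which makes compound 3 the least tolerated of the three and shows that the outer part of the chain matters as well. The step from compound 2 gives only a minimum size, as compound 2 carries a limit and not a number: the limit of >= 200000 nM in this assay, at which 1 of the 3 values shown sits.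

Compounds 1 and 3 differ in both the length and the end of the chain, so the shift cannot be assigned to either one alone. As far as these compounds go, it remains open whether 2-carbamoylethyl is itself the low point, or whether a longer chain ending in the same carbamoyl, or a chain of the same length ending in a carboxylic acid or an amine, would fall lower still.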